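Swapping a bromophenyl for a chloro-fluorophenyl on the chalcone arm

This account rests on a few compounds, and the source may have more. Where it says the series, first, only, none or still open, it means among the compounds named here.

Three compounds of a shared core have so far been looked at in an ADME assay on cells (Macrophage) for cytotoxicity, read by resazurin assay, with a stated time of 48 h; on this read-out lower numbers stand for higher toxicity in this test and higher numbers for lower toxicity in this test. Compound 1, with structure `C#CCOc1ccc(/C=C/C(=O)c2ccc(OCc3cn(Cc4ccccc4)nn3)cc2O)cc1`, has no recorded result in this assay: its entry reads "not determined" (no result reported). Compound 2, with structure `O=C(/C=C/c1ccc(Br)cc1)c1ccc(OCc2cn(Cc3ccc(Br)cc3)nn2)cc1O`, likewise has no single number in this assay; its entry stands as "not determined" (no result reported). For compound 3, with structure `CCCCCCn1cc(COc2ccc(C(=O)/C=C/c3ccc(Br)cc3)c(O)c2)nn1`, only a limit of the assay is recorded, not a number: it gives > 100000 nM. So among the three entries for this assay, one is a limit and two hold no value at all, and compound 2 is one of the two without a value.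

Compound 4, with structure `O=C(/C=C/c1c(F)cccc1Cl)c1ccc(OCc2cn(Cc3ccc(Br)cc3)nn2)cc1O`, differs from compound 2 in one place: 2-chloro-6-fluorophenyl in place of 4-bromophenyl on a double-bonded chain carbon bound to a double-bonded chain carbon. No measured pair among these compounds differs in a single place, so no step of known size can be drawn from the data in this assay. Among the compounds with values here, the one point of evidence is the limit of > 100000 nM in this assay, at which 1 of the 3 values shown sits, which is a limit and not a number. Because of the limit of > 100000 nM in this assay, at which 1 of the 3 values shown sits, compound 4 is expected to sit near that same limit, with little or no change beyond the usual scatter. Compound 4 is estimated at 100000 nM, within a range from 30000 nM to 300000 nM.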

Compound 4, half-maximal cytotoxic concentration: 65800 nM
For compound 4 the middle estimate is 1.5-fold (0.18 log units) above the measured one; measured number inside the range.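

In this assay, within the data shown here, compound 2 holds no single number, while compound 4 gives 65800 nM, so no step between compound 2 and compound 4 can be read. The compounds shown leave open how far the change from 4-bromophenyl to 2-chloro-6-fluorophenyl, taken on its own, moves this cytotoxicity read-out.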